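The source may report more compounds than this note shows. Statements on the series, on what has been measured and on what is new or still open speak of the compounds shown alone.

In an ADME assay on Caco-2 cells (Homo sapiens) for permeability, read by LC-MS, with a stated time of 2 h, at pH 7.4, tested at 10 uM (a higher number here means that the compound crosses the layer faster, a lower number that the compound crosses the layer more slowly), compound 1 `O=C(c1cccc(C(F)(F)c2n[nH]c(=O)c3c2CCCC3)c1)N1CCn2c(nnc2C(F)(F)F)C1` gives 1.3 10^-6 cm/s while compound 2 `C[C@@H]1Cn2c(nnc2C(F)(F)F)CN1C(=O)c1cccc(C(F)(F)c2n[nH]c(=O)c3c2CCCC3)c1` gives 1.8 10^-6 cm/s and compound 3 `C[C@H]1Cn2c(nnc2C(F)(F)F)CN1C(=O)c1cccc(C(F)(F)c2n[nH]c(=O)c3c2CCCC3)c1` gives 3.6 10^-6 cm/s on the same read-out. Compound 2 sits within the scatter of both others, as a 1.4-fold higher number from compound 1 to compound 2 (0.14 log units; within the scatter) and a 2.0-fold higher number from compound 2 to compound 3 (0.30 log units; within the scatter) show. Only a 2.8-fold higher number from compound 1 to compound 3 (0.44 log units; beyond the scatter) goes beyond it.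

Compound 4 `C[C@@H]1Cn2c(nnc2C(F)(F)F)CN1C(=O)c1cccc(C(F)(F)c2n[nH]c(=O)c3ccccc23)c1` differs from compound 2 by a group of 11 heavy atoms (8 carbon, 2 nitrogen, 1 oxygen; one six-membered aromatic ring of carbon only, one six-membered aromatic ring with 2 hetero atoms) in place of a group of 11 heavy atoms (8 carbon, 2 nitrogen, 1 oxygen; one six-membered non-aromatic ring of carbon only, one six-membered aromatic ring with 2 hetero atoms), on a saturated chain carbon bound to an aromatic carbon and two fluorine atoms and so carries an aromatic carbon ring where the non-aromatic one stood. Among the compounds with values here, no measured step touches this place. The steps in hand cover methyl in place of hydrogen on a saturated ring carbon and (the fact that compounds 2 and 3 differ only in the configuration as drawn), so they give only a sense of how far numbers move in this series. The expectation therefore stays anchored on compound 2 at 1.8 10^-6 cm/s with no move beyond the scatter. The expected step is a 1.1-fold higher number from compound 2 to compound 4 (0.05 log units; within the scatter) in this assay. For compound 4 the estimated value is 2 10^-6 cm/s, with an expected range of 0.9 10^-6 cm/s to 4.5 10^-6 cm/s.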

Compound 4, apparent permeability: 7.9 10^-6 cm/s
Estimate against measurement, compound 4: 4.0-fold (0.60 log units) below, outside the stated range (above it).
By their numbers in this assay, from the lowest: compounds 1, 2 and 3 (each within the scatter of the next, the first and the last beyond it); then compound 4.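

In this assay, within the data shown here, the aromatic carbon ring in place of the non-aromatic one, on a saturated chain carbon bound to an aromatic carbon and two fluorine atoms, gives a 4.4-fold higher number from compound 2 to compound 4 (0.64 log units; beyond the scatter), the first reading of a change at this place, since the earlier steps covered only the methyl on a saturated ring carbon and its configuration. The leaving and entering groups have the same counts of heavy atoms, hydrogen-bond donors and hydrogen-bond acceptors and the same net charge, so the step comes with a change of ring type and no change in those counts. Nothing measured here gives a reason for this step.

From the compounds shown here alone, it remains open whether the same ring change gives a step of like size on compound 1 or compound 3. Also open, going by these compounds, is how a pyridine ring would read in place of the aromatic carbon ring.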